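The source may hold more compounds than are shown below. What is called first, only, known or untested is meant among the compounds shown, and "the series" means these compounds.

In a functional assay on A549 cells (Homo sapiens) for antiproliferative activity, read by MTT assay, with a stated time of 72 h (a higher number here means a weaker inhibitor, a lower number a stronger inhibitor), compound 3 (`COc1cc(-n2cnc3ccc(-c4ccccc4)cc32)cc(OC)c1OC`), which carries a plain phenyl, gives 3060 nM, the lowest number of the three measured compounds. Compound 2 (`COc1cc(-n2cnc3ccc(-c4cc(F)ccc4F)cc32)cc(OC)c1OC`), with a 2,5-difluorophenyl in that place, gives 7940 nM. Compound 1 (`COc1cc(-n2cnc3ccc(-c4ccc(C)cc4F)cc32)cc(OC)c1OC`), with a 2-fluoro-4-methylphenyl, reads > 10000 nM, which is a limit of the assay and not a number.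

Compound 4 (`COc1cc(-n2cnc3ccc(-c4ccc(C(F)(F)F)cc4)cc32)cc(OC)c1OC`) has trifluoromethyl in place of hydrogen on an aromatic carbon of the phenyl of compound 3, para to a large group: trifluoromethyl in place of hydrogen on an aromatic carbon. Going by the values given here, no measured step adds this group. The nearest guides are two steps that go back to plain phenyl, a 2.6-fold lower number from compound 2 to compound 3 (0.41 log units; beyond the scatter) and an at least 3.2-fold lower number from compound 1 to compound 3 (0.51 log units; beyond the scatter). Both show that the substituted compounds have higher numbers, and neither measured compound goes against this, though two examples are few.

A modest rise in this assay is therefore expected, with an estimated 2.3-fold higher number from compound 3 to compound 4 (0.36 log units; beyond the scatter). The estimate for compound 4 is 7000 nM, with an expected range from 2500 nM to 18000 nM.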

Compound 4, half-maximal inhibitory concentration: 3390 nM
Compound 4: the middle estimate sits 2.1-fold (0.31 log units) above what was measured, within the range that was stated.
By their numbers in this assay, from the lowest: compounds 3 and 4 (each within the scatter of the next); then compound 2. At a limit, above all of these: compound 1.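

In this assay, placing trifluoromethyl on the phenyl of compound 3, para to a large group, gives a 1.1-fold higher number from compound 3 to compound 4 (0.04 log units; within the scatter), so this change leaves no reading that can be told apart from plain phenyl. Until now every substituted ring had carried a higher number than plain phenyl, but a substituent need not raise the number: 4-(trifluoromethyl)phenyl shows a 2.3-fold lower number from compound 2 to compound 4 (0.37 log units; beyond the scatter) and an at least 2.9-fold lower number from compound 1 to compound 4 (0.46 log units; beyond the scatter). The second of these steps is only a floor, since compound 1 reads at a limit of the assay and not a number: the limit of > 10000 nM in this assay, at which 1 of the 4 values shown sits.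

The compounds shown cannot say whether other groups at this place, such as an amine or a carboxylic acid, would also leave the reading unchanged. Going by these compounds, they also show trifluoromethyl at only this one place on the ring, so its effect elsewhere on the ring remains open.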